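The source may report more compounds than this note shows. Statements on the series, on what has been measured and on what is new or still open speak of the compounds shown alone.

Of the compounds shown here, two sharing one core have been measured in a physicochemical assay for metabolic stability, read by LC-MS, in simulated gastric fluid, with a stated time of 15 min, tested at 50 uM; on this read-out higher numbers stand for a more stable compound and lower numbers for a less stable compound. Compound 1 `CCC(C)c1ccccc1OC(=O)c1coc(-c2ccccc2)n1` gives 0.2% in this assay, the lower of the two numbers recorded, although the gap to its nearest neighbour lies within the usual scatter. Compound 2 `Cc1ccc(Cl)c(OC(=O)c2coc(-c3ccccc3)n2)c1` gives 0.9% in this assay, so close to compound 1 that neither can be called the more stable of the two. Both numbers sit near the bottom of the scale, meaning almost none of either compound remains after the stated time.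

Compound 3 `O=C(Oc1ccccc1)c1coc(-c2ccccc2)n1` has not yet been measured. It differs from compound 1 in one place: hydrogen in place of sec-butyl on an aromatic carbon. With both measured compounds barely surviving, the step expected in this assay is a number 0.3 percentage points higher from compound 1 to compound 3 (within the scatter), which amounts to no movement beyond the scatter. Compound 3 is accordingly expected to give 0.5%, with a range from 0% to 5%.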

Compound 3, percent of the compound remaining: 0.2%
Beside the measured number, compound 3's estimate is 0.3 percentage points above it, within the range that was stated.
By their numbers in this assay, from the lowest: compounds 1, 3 and 2 (each within the scatter of the next).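

In this assay, replacing sec-butyl with hydrogen on this aromatic carbon gives no change at the digits printed from compound 1 to compound 3 (within the scatter). The earlier pair differed in more than one place, whereas this single change shows that the very low number of compound 1 does not depend on having sec-butyl at this position: the compound with only hydrogen there barely survives either. No measurement shown here explains this lack of movement or identifies what is lost from the compounds during the test.

With the number already so close to the bottom of the scale, any further loss of stability from a change at this position would be hard to see. Still open, going by these compounds, is whether a different group on this aromatic carbon, such as an amine, a carboxylic acid or a longer carbon chain, could raise the number beyond the scatter.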